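The source may hold more compounds than are shown below. What is called first, only, known or untested is meant among the compounds shown, and "the series" means these compounds.

In a functional assay on Huh-5-2 cells (Homo sapiens) for cytotoxicity, read by microscopy (on this read-out higher numbers stand for lower toxicity in this test and lower numbers for higher toxicity in this test), compound 1 (`O=c1oc2ccccc2cc1CSc1nc2cncnc2n1[C@@H]1O[C@H](CO)[C@@H](O)[C@H]1O`) gives 50000 nM. Its fluoro relative, compound 2 (`O=c1oc2ccc(F)cc2cc1CSc1nc2cncnc2n1[C@@H]1O[C@H](CO)[C@@H](O)[C@H]1O`), gives 36000 nM, and its chloro relative, compound 3 (`O=c1oc2ccc(Cl)cc2cc1CSc1nc2cncnc2n1[C@@H]1O[C@H](CO)[C@@H](O)[C@H]1O`), gives 37000 nM. These three numbers lie within the scatter of one another, so compound 1 stands level with both relatives. Compound 4 (`Nc1ncnc2c1nc(SCc1cc3ccccc3oc1=O)n2[C@@H]1O[C@H](CO)[C@@H](O)[C@H]1O`) differs from compound 1 by amino in place of hydrogen on an aromatic carbon. The nearest guides are two measured steps, both within the scatter: a 1.4-fold lower number from compound 1 to compound 2 (0.14 log units; within the scatter) and a 1.4-fold lower number from compound 1 to compound 3 (0.13 log units; within the scatter). Neither step introduces an amino group, so they offer only loose guidance here. No shift beyond the scatter is expected, and the estimated step is a 1.3-fold lower number from compound 1 to compound 4 (0.10 log units; within the scatter). For compound 4 the estimated value is 40000 nM, with an expected range from 15000 nM to 90000 nM.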

Compound 4, half-maximal cytotoxic concentration: 49000 nM
Beside the measured number, compound 4's estimate is 1.2-fold (0.09 log units) below it; the range from low to high includes it.
By their numbers in this assay, from the lowest: compounds 2, 3, 4 and 1 (each within the scatter of the next).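

In this assay the step is a 1.0-fold lower number from compound 1 to compound 4 (0.01 log units; within the scatter) for amino in place of hydrogen on an aromatic carbon of a six-membered aromatic ring with 2 nitrogen. For the compounds shown here, the fluoro and chloro changes sat at a different place, so this is the first sign that a change at this position also leaves the read-out within the scatter. No measurement at hand explains this result. From the compounds shown here alone, whether a larger group here, such as dimethylamino or methoxy, would also stay within the scatter remains open. So does the outcome of combining amino with fluoro or chloro.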